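From acetyl to ethoxycarbonyl in an antiproliferative series

This account rests on a few compounds, and the source may have more. Where it says the series, first, only, none or still open, it means among the compounds named here.

Measured in a functional assay on Huh-7 cells (Homo sapiens) for antiproliferative activity, with a stated time of 48 h; on this read-out lower numbers stand for stronger inhibition and higher numbers for weaker inhibition:
compound 1 `COC(=O)c1cccc(-c2ccc(-n3cccc3)nn2)c1` gives 30000 nM
compound 2 `COc1ccc(Nc2ccc(-c3ccccc3)nn2)cc1` gives 30000 nM
compound 3 `CCN(CC)c1ccc(-c2ccc(C(C)=O)cc2)nn1` gives 25000 nM

Compound 3 stands within the scatter of both compound 1 and compound 2, so the three cannot be told apart. Compound 4 `CCOC(=O)c1ccc(-c2ccc(N(CC)CC)nn2)cc1` differs from compound 3 in one place, with ethoxy in place of methyl on a carbonyl carbon. Within the data shown here, no measured pair shows this change alone. The three measured values sit close together despite their different structures, so no step beyond the scatter is expected in this assay and no direction is favoured. The expected step is no change at the digits printed from compound 3 to compound 4 (within the scatter) by this estimate. For compound 4 the estimated value is 25000 nM (expected range 10000 nM to 50000 nM).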

Compound 4, half-maximal inhibitory concentration: 9000 nM
The estimate for compound 4 lay 2.8-fold (0.44 log units) above the measured number; the whole stated range lies above it.
By their numbers in this assay, from the lowest: compound 4; then compounds 3, 1 and 2 (each within the scatter of the next).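

In this assay, ethoxy in place of methyl on a carbonyl carbon gives a 2.8-fold lower number from compound 3 to compound 4 (0.44 log units; beyond the scatter). This is the first step shown that lies beyond the scatter, so this position responds to the change, although the step is modest. No measured evidence bears on why the number falls.

The compounds shown leave open whether the oxygen or the longer chain carries the step. A propyl group on the same carbonyl carbon, or a carboxylic acid in place of the ethoxycarbonyl, would help to separate the two.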